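Methoxy in place of hydrogen on the aryl ring of compound 3

The source may hold more compounds than are shown below. What is called first, only, known or untested is meant among the compounds shown, and "the series" means these compounds.

Of the compounds shown here, three have been measured in a functional assay on T47D cells (Homo sapiens) for inhibition, read by sulforhodamine B assay, with a stated time of 48 h; a lower number here means a stronger inhibitor of growth, a higher number a weaker inhibitor of growth. Compound 1 `O=C(/C(=C/c1ccccc1)CCl)c1ccccc1` gives 18000 nM. Compound 2 `CC(=O)OC/C(=C/c1ccccc1Br)C(=O)c1ccccc1` gives 18000 nM. Compound 3 `C=C(C/C(=C\c1ccccc1)C(=O)c1ccccc1)C(=O)c1ccccc1` gives 15000 nM. Compound 3 thus carries the lowest number of the three, yet both compound 1 and compound 2 sit within the usual scatter of it, so the three values cannot be told apart and no order among them can be read. Going by the values given here, no single-point step between measured compounds is available.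

Compound 4 `C=C(C/C(=C\c1ccc(OC)cc1)C(=O)c1ccccc1)C(=O)c1ccccc1` has not been measured. It differs from compound 3 by methoxy in place of hydrogen on an aromatic carbon. Nothing in the measured set shows what such a change does in this assay, so there is no ground to expect a move beyond the scatter in either direction. The expected step is no change at the digits printed from compound 3 to compound 4 (within the scatter), that is, none beyond the scatter. Compound 4 is therefore estimated at 15000 nM, with a range from 7000 nM to 32000 nM.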

Compound 4, concentration for 50% growth inhibition: 370 nM
Estimate against measurement, compound 4: 41-fold (1.61 log units) above; the measured number lies below the stated range.
By their numbers in this assay, from the lowest: compound 4; then compounds 3, 1 and 2 (each within the scatter of the next).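

In this assay, methoxy in place of hydrogen on an aromatic carbon, para to a large group, gives a 41-fold lower number from compound 3 to compound 4 (1.61 log units; beyond the scatter). Going by these compounds alone, the earlier compounds offered no step in a single place, so this is the first sign that the series responds to a change at this position, and the step rests on this one pair alone. Nothing available here accounts for the size of this step.

Going by these compounds, whether the lower number belongs to methoxy itself remains open, since no other group at this carbon, such as hydroxy, ethoxy or an amine, stands beside it. Also open, on these data alone, is whether the same change would carry over to the cores of compound 1 and compound 2, or would act in the same way elsewhere on the aryl ring.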